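The source may hold more compounds than are shown below. What is called first, only, known or untested is meant among the compounds shown, and "the series" means these compounds.

Measured compounds:
compound 1 `COc1ccc(C(c2ccccc2)c2nc(-c3ccc(Cl)cc3)c(CC(=O)O)s2)cc1`, 76 nM
compound 2 `O=C(O)Cc1sc(C(c2ccccc2)c2ccccn2)nc1-c1ccc(Cl)cc1`, 1900 nM

In an in vitro functional assay on HEK285-7 cells for antagonist activity at prostaglandin D2 receptor 2 (Homo sapiens), read by BRET and beta-arrestin recruitment (a higher number here means a weaker inhibitor, a lower number a stronger inhibitor), compound 1 gives 76 nM while compound 2 gives 1900 nM. Compound 2 thus stands at the highest of the two numbers, separated from compound 1 by the step of a 25-fold higher number from compound 1 to compound 2 (1.40 log units; beyond the scatter), which lies beyond the scatter. Compound 3 `COc1ccc(C(c2ccccn2)c2nc(-c3ccc(Cl)cc3)c(CC(=O)O)s2)cc1` has not yet been measured. It differs from compound 2 by methoxy in place of hydrogen on an aromatic carbon. For the measured compounds named here, no measured step bears directly on this change: the only step known, a 25-fold higher number from compound 1 to compound 2 (1.40 log units; beyond the scatter), exchanges one of the two aromatic groups on the saturated chain carbon for pyridin-2-yl and says nothing about adding methoxy to the remaining phenyl. The expectation for compound 3 is therefore a modest shift of uncertain direction, estimated as a 1.9-fold lower number from compound 2 to compound 3 (0.28 log units; within the scatter). Compound 3 is expected to give about 1000 nM, with a range from 300 nM to 3000 nM.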

Compound 3, half-maximal inhibitory concentration: 310 nM
The estimate for compound 3 lay 3.2-fold (0.51 log units) above the measured number; the range from low to high includes it.
By their numbers in this assay, from the lowest: compound 1; then compound 3; then compound 2.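

Turning the phenyl of compound 2 into 4-methoxyphenyl gives a 6.1-fold lower number from compound 2 to compound 3 (0.79 log units; beyond the scatter) in this assay and shows that this position responds to methoxy even with pyridin-2-yl on the same saturated carbon. With 4-methoxyphenyl held constant, the exchange of phenyl for pyridin-2-yl still gives a 4.1-fold higher number from compound 1 to compound 3 (0.61 log units; beyond the scatter) and shows that this exchange remains unfavourable in the methoxy series, with compound 3 falling between compound 1 and compound 2. Nothing available explains either step.

The compounds shown leave open how fluorine, a hydroxyl group or a dimethylamino group would read at the place taken by methoxy. They also leave open whether methoxy would produce a step of similar size with phenyl in place of pyridin-2-yl on the saturated carbon.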